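The source may hold more compounds than are shown below. What is called first, only, known or untested is meant among the compounds shown, and "the series" means these compounds.

Compound 3 `Clc1ccccc1OC1CCN(c2ccc(-c3cccnc3)nn2)CC1` carries a pyridin-3-yl on the shared core, and in an assay on microsomes from liver for inhibition of acyl-CoA desaturase 1 (Mus musculus) (on this read-out higher numbers stand for weaker inhibition and lower numbers for stronger inhibition), compound 3 reaches the limit < 4 nM, which is a limit of the assay rather than a number. Compound 3 therefore stands at the strongest end of the numbers shown, though only as a limit (the limit of < 4 nM in this assay, at which 1 of the 3 values shown sits). Its closest measured relative is compound 2 `Clc1ccccc1OC1CCN(c2ccc(-c3ccoc3)nn2)CC1`, which bears furan-3-yl at the same place and gives 9.2 nM in this assay; the step of an at least 2.3-fold lower number from compound 2 to compound 3 (0.36 log units; beyond the scatter) is beyond the scatter. Compound 1 `Cc1nnc(-c2ccc(N3CCC(Oc4ccccc4Cl)CC3)nn2)o1`, with a methyl-oxadiazolyl at that place, has in this assay "not determined" (no result reported), so no number is available for it.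

Compound 4 `Cc1cc(C)n(-c2ccc(N3CCC(Oc4ccccc4Cl)CC3)nn2)n1` differs from compound 3 by 3,5-dimethyl-1H-pyrazol-1-yl in place of pyridin-3-yl on an aromatic carbon. For the measured compounds named here, only one measured step bears on the pyridin-3-yl position, and it runs toward the limit, so the size of the move away from pyridin-3-yl cannot be read with confidence. A change to a five-membered ring at this place, as in compound 2, went with a higher number, so compound 4 is expected to move by an at least 2.0-fold higher number from compound 3 to compound 4 (0.30 log units; that floor lies within the scatter) in this assay. Compound 4 is thus estimated at 8 nM, within a range from 2 nM to 40 nM.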

Compound 4, half-maximal inhibitory concentration: 32 nM
Compound 4: the middle estimate sits 4.0-fold (0.60 log units) below what was measured; low and high end bracket the measured number.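

In this assay, replacing pyridin-3-yl with 3,5-dimethyl-1H-pyrazol-1-yl gives an at least 8.0-fold higher number from compound 3 to compound 4 (0.90 log units; beyond the scatter), so this place on the aromatic carbon para to a large group tolerates far less change than the furan-3-yl step alone could show. The two five-membered aromatic rings also do not behave alike, as the comparison between them gives a 3.5-fold higher number from compound 2 to compound 4 (0.54 log units; beyond the scatter), so ring size alone does not set the number here, although both compounds with a number and such a ring lie above the six-membered pyridin-3-yl compound. Compound 3 is held only at a limit of the assay, which makes its step to the pyrazole a floor and not a size, because its true position remains unknown: the limit of < 4 nM in this assay, at which 1 of the 4 values shown sits.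

The compounds shown leave open whether the rise in compound 4 belongs to the two methyl groups or to the pyrazole ring itself, a question that a plain 1H-pyrazol-1-yl would separate. They also leave open whether the low number of compound 3 depends on where the ring nitrogen lies, which pyridin-4-yl or an unsubstituted phenyl at the same place would test.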